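This account rests on a few compounds, and the source may have more. Where it says the series, first, only, none or still open, it means among the compounds named here.

Measured so far in an ADME assay on microsomes from liver (Mus musculus) for metabolic stability, read by LC-MS, with a stated time of 10 min; on this read-out higher numbers stand for a more stable compound and lower numbers for a less stable compound:

Compound 1, `CN(C[C@H]1Cc2c(cccc2N2CCN(C3CC3)CC2)CN1)[C@H]1CCCc2cccnc21`: 7%
Compound 2, `CCN1CCN(c2cccc3c2C[C@H](CN(C)[C@H]2CCCc4cccnc42)NC3)CC1`: 18.8%
Compound 3, `CC(C)N1CCN(c2cccc3c2C[C@H](CN(C)[C@H]2CCCc4cccnc42)NC3)CC1`: 15.1%

Compound 3 stands second highest of the three numbers. Its nearest neighbour is compound 2, and the two values lie within the scatter of each other, as do the values of compound 3 and compound 1, so no order among them is secure. Among the compounds with values here, the one step that reached beyond the scatter was a number 11.8 percentage points higher from compound 1 to compound 2 (beyond the scatter), a modest gain; a number 8.1 percentage points higher from compound 1 to compound 3 (within the scatter) and a number 3.7 percentage points lower from compound 2 to compound 3 (within the scatter) stayed within it.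

Compound 4, `CN(C[C@H]1Cc2c(cccc2N2CCN3CCC[C@H]3C2)CN1)[C@H]1CCCc2cccnc21`, differs from compound 3 as follows: a group of 9 heavy atoms (7 carbon, 2 nitrogen; one five-membered non-aromatic ring with 1 hetero atom, one six-membered non-aromatic ring with 2 hetero atoms) in place of a group of 9 heavy atoms (7 carbon, 2 nitrogen; one six-membered non-aromatic ring with 2 hetero atoms), on an aromatic carbon

All three measured steps changed only the group on one amine nitrogen of the six-membered ring that now leaves, so none of them tests the entering group directly. What they show is that changes at this position have moved this assay by at most a modest amount. A step of similar scale, in either direction, is therefore the most that is expected from compound 3 to compound 4: a number 1.1 percentage points lower from compound 3 to compound 4 (within the scatter). Compound 4 is estimated at 14%, with a range from 5% to 30%.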

Compound 4, percent of the compound remaining: 40.1%
The estimate for compound 4 lay 26.1 percentage points below the measured number, and the stated range ends below it.
By their numbers in this assay, from the lowest: compounds 1, 3 and 2 (each within the scatter of the next, the first and the last beyond it); then compound 4.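

In this assay, the group on the aromatic carbon proves able to shift the number by more than any swap of the small group on the ring nitrogen did: a number 25 percentage points higher from compound 3 to compound 4 (beyond the scatter), a number 21.3 percentage points higher from compound 2 to compound 4 (beyond the scatter) and a number 33.1 percentage points higher from compound 1 to compound 4 (beyond the scatter). The entering group holds a five-membered non-aromatic ring as well as the six-membered one, yet it has the same counts of heavy atoms, carbon and nitrogen as 4-isopropylpiperazin-1-yl, so the gain from compound 3 to compound 4 goes with how those atoms are arranged, not how many there are. Nothing shown here gives a measured reason for this gain.

On these data alone, it remains open whether the defined stereocentre matters, which the mirror-image form of the entering group would test. As far as these compounds go, it is also open whether a second ring of another size, such as a six-membered carbon-containing ring in place of the five-membered one, would behave alike.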